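Lengthening the Chain on the Aromatic Nitrogen

The compounds below may be only part of what the source reports. "The series", "measured", "known", "first", "only" and "open" are said of these compounds alone.

compound 1 `Cn1ncnc1-c1ccccc1NCC1=NCCN1`: 39.8 nM
compound 2 `CCn1ncnc1-c1ccccc1NCC1=NCCN1`: 63.1 nM

In an in vitro functional assay on cells (Fibroblast) for agonist activity at Alpha-1B adrenergic receptor (Homo sapiens) (a higher number here means that more compound is needed for the effect, a lower number that less compound is needed), compound 2 stands highest of the two numbers shown, though the single measured step, a 1.6-fold higher number from compound 1 to compound 2 (0.20 log units; within the scatter), lies within the scatter. Compound 3 `CCCCn1ncnc1-c1ccccc1NCC1=NCCN1` differs from compound 2 by ethyl in place of hydrogen on a saturated chain carbon, two bonds along the chain from an aromatic nitrogen. Going by the values given here, the only step that bears on this change is a 1.6-fold higher number from compound 1 to compound 2 (0.20 log units; within the scatter), a chain lengthening at the same nitrogen that barely moved the number. Compound 3 is therefore expected to shift little, if anything toward a higher number, a 1.6-fold higher number from compound 2 to compound 3 (0.20 log units; within the scatter). Compound 3 is estimated at 100 nM, within 40 nM to 250 nM.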

Compound 3, half-maximal effective concentration: 200 nM
Estimate against measurement, compound 3: 2.0-fold (0.30 log units) below; measured number inside the range.
By their numbers in this assay, from the lowest: compounds 1 and 2 (each within the scatter of the next); then compound 3.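

Going by these compounds alone, the chain on the aromatic nitrogen now has a visible effect in this assay: ethyl in place of hydrogen, two bonds along the chain, gives a 3.2-fold higher number from compound 2 to compound 3 (0.50 log units; beyond the scatter) and is the first step here beyond the scatter. Propyl in place of hydrogen on the chain carbon bound to the aromatic nitrogen gives a 5.0-fold higher number from compound 1 to compound 3 (0.70 log units; beyond the scatter), so compound 3 stands above both shorter-chain compounds. No measurement shown accounts for this change. On these data alone, whether a longer chain would raise the number further remains open, as does the outcome with a branched isopropyl group or a chain ending in an amine.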